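Two chlorines added to a slowly cleared compound

A few compounds are considered here, and "the series" means these few. Any claim that something is new, unique, unknown or untested is made for them only; others in the source may bear on it.

Compound 3 `O=C(N[C@H]1CN(S(=O)(=O)c2ccccc2)C[C@@H]1C(=O)N[C@H]1CCCNC1)c1cc(-c2ccccc2)on1` gives < 3 mL.min-1.g-1 in an ADME assay on microsomes from liver (Homo sapiens) for metabolic stability (a lower number here means slower removal, a higher number faster removal of the compound), as a limit, not a number. Compound 1 `Cc1ccc2[nH]c(C(=O)N[C@H]3CN(S(=O)(=O)c4ccccc4)C[C@@H]3C(=O)N[C@H]3CCCNC3)cc2c1` gives < 3 mL.min-1.g-1 as a limit too. Compound 2 `Cc1csc(C(=O)N[C@H]2CN(S(=O)(=O)c3ccccc3)C[C@@H]2C(=O)N[C@H]2CCCNC2)n1` gives 9.1 mL.min-1.g-1 as a true number.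

Compound 4 `O=C(N[C@H]1CN(S(=O)(=O)c2ccccc2)C[C@@H]1C(=O)N[C@H]1CCCNC1)c1cc(-c2ccc(Cl)cc2Cl)on1` carries 2,4-dichlorophenyl in place of phenyl on an aromatic carbon and otherwise matches compound 3. Among the compounds with values here, no measured step changes this group alone. The nearest ones swap the whole group on the carbonyl carbon, giving an at least 3.0-fold higher number from compound 1 to compound 2 (0.48 log units; beyond the scatter) and an at least 3.0-fold lower number from compound 2 to compound 3 (0.48 log units; beyond the scatter) as well as a step that the two limits leave unreadable from compound 1 to compound 3 in this data set. A modest rise in this assay is therefore expected, with the estimated step being an at least 1.3-fold higher number from compound 3 to compound 4 (0.12 log units; that floor lies within the scatter) and perhaps staying within the scatter. The estimate for compound 4 is 4 mL.min-1.g-1 (expected range 2 mL.min-1.g-1 to 12 mL.min-1.g-1).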

Compound 4, intrinsic clearance in microsomes: < 3 mL.min-1.g-1
Compound 4: a limit, no number; the forecaster's own chance of this, stated with the estimate: 40%; middle value at least 1.3-fold (0.12 log units) from the limit.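

In this assay compound 4 gives < 3 mL.min-1.g-1, a limit and not a number. Compound 3 gives < 3 mL.min-1.g-1, also a limit. No step can be read between compound 3 and compound 4, because both rest on the same limit: the limit of < 3 mL.min-1.g-1 in this assay, at which 3 of the 4 values shown sit. As far as these compounds go, how far 2,4-dichlorophenyl in place of phenyl shifts the number in this assay stays open.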